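From 4-Chlorophenyl to Naphthalen-2-yl on a Shared Core

This account rests on a few compounds, and the source may have more. Where it says the series, first, only, none or still open, it means among the compounds named here.

In a functional assay on A2780 cells (Homo sapiens) for inhibition, read by MTT assay, with a stated time of 72 h (on this read-out higher numbers stand for weaker inhibition and lower numbers for stronger inhibition), compound 2 `O=C1/C(=C\c2ccccc2)c2c(ncn2COCc2ccccc2)CCN1Cc1ccc(Cl)cc1` gives 22200 nM. Going by the values given here, only one close relative has a number so far, and compound 1 `Cc1cccc(CN2CCc3ncn(COCc4ccccc4)c3/C(=C/c3ccccc3)C2=O)c1` gives 26300 nM. These two values lie within the scatter of each other, so the two compounds stand level on this read-out.

The next compound, compound 3 `O=C1/C(=C\c2ccccc2)c2c(ncn2COCc2ccccc2)CCN1Cc1ccc2ccccc2c1`, keeps the shared core and changes a single group: naphthalen-2-yl in place of 4-chlorophenyl on a saturated chain carbon bound to an amide-type nitrogen in a ring. Among the compounds with values here, one measured step bears on this place in the molecule, a 1.2-fold lower number from compound 1 to compound 2 (0.07 log units; within the scatter). That swap of 3-methylphenyl for 4-chlorophenyl did not move the number beyond the scatter. Within the data shown here, it is a single step, however, and no measured compound carries naphthalen-2-yl, so the evidence is thin. The data offer no reason to expect a change in either direction beyond the scatter in this assay, though the uncertainty is wide. The expected change is a 1.1-fold lower number from compound 2 to compound 3 (0.05 log units; within the scatter). For compound 3, the estimated value is 20000 nM, with an expected range from 9000 nM to 40000 nM.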

Compound 3, half-maximal inhibitory concentration: 72800 nM
Beside the measured number, compound 3's estimate is 3.6-fold (0.56 log units) below it; the whole stated range lies below it.
By their numbers in this assay, from the lowest: compounds 2 and 1 (each within the scatter of the next); then compound 3.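

In this assay, going by these compounds alone, this place on a saturated chain carbon bound to an amide-type nitrogen in a ring proves sensitive to what it carries: naphthalen-2-yl in place of 4-chlorophenyl gives a 3.3-fold higher number from compound 2 to compound 3 (0.52 log units; beyond the scatter), the first step in this set to pass beyond the scatter, whereas a 1.2-fold lower number from compound 1 to compound 2 (0.07 log units; within the scatter) stayed within it. The comparison with 3-methylphenyl points the same way, with a 2.8-fold higher number from compound 1 to compound 3 (0.44 log units; beyond the scatter), so among these three compounds the two groups with one aromatic ring stand level and the group with two aromatic rings gives weaker inhibition, a modest loss rather than a large one. No measurement offered here explains this loss.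

The change from 4-chlorophenyl to naphthalen-2-yl adds a second aromatic ring and removes the chlorine in one move, so these compounds cannot separate the two changes, and a plain phenyl or a naphthalen-1-yl group would be needed to divide them. How an amine, a carboxylic acid or a longer chain at this place would affect the number also remains open, as all three groups shown are carbon-based aromatic rings with no hydrogen-bond donors or acceptors.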